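The source may report more compounds than this note shows. Statements on the series, on what has been measured and on what is new or still open speak of the compounds shown alone.

Measured in a functional assay on brain (Rattus norvegicus, strain Wistar) for inhibition; a higher number here means a weaker inhibitor, a lower number a stronger inhibitor:
- Compound 1 `COc1ccc(-c2c(C)[nH]c(=O)n2C)cc1`: 147000 nM
- Compound 2 `Cc1[nH]c(=O)n(C)c1-c1ccc(OC(C)C)cc1`: 20400 nM
- Compound 3 `Cc1[nH]c(=O)n(C)c1-c1ccc(CC(C)C)cc1`: 7800 nM

Compound 3 holds the lowest number of the three, with compound 2 nearest to it and compound 1 furthest away. The next compound is compound 4 `CCCCCOc1ccc(-c2c(C)[nH]c(=O)n2C)cc1`, with pentyloxy in place of isobutyl on an aromatic carbon.

Going by the values given here, three measured steps bear on this change. Isopropyl in place of methyl on the oxygen gave a 7.2-fold lower number from compound 1 to compound 2 (0.86 log units; beyond the scatter), a modest step that favours a larger group on the oxygen, though it rests on one pair. Isobutyl in place of methoxy gave a 19-fold lower number from compound 1 to compound 3 (1.28 log units; beyond the scatter), a large step. Isobutyl in place of isopropoxy gave a 2.6-fold lower number from compound 2 to compound 3 (0.42 log units; beyond the scatter), again modest, so removing the oxygen also lowered the number. Among the compounds with values here, no measured compound carries pentyloxy.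

A small downward step in this assay is therefore expected, possibly within the scatter. The estimated step is a 1.6-fold lower number from compound 3 to compound 4 (0.19 log units; within the scatter). For compound 4 the expected value is 5000 nM, with an estimated range from 1500 nM to 15000 nM.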

Compound 4, half-maximal inhibitory concentration: 4500 nM
Beside the measured number, compound 4's estimate is 1.1-fold (0.05 log units) above it; the range from low to high includes it.
By their numbers in this assay, from the lowest: compounds 4 and 3 (each within the scatter of the next); then compound 2; then compound 1.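

In this assay, a longer chain on the oxygen went with a lower number across the three ethers: pentyl in place of isopropyl gave a 4.5-fold lower number from compound 2 to compound 4 (0.66 log units; beyond the scatter), and the full extension from the methoxy group gave a 33-fold lower number from compound 1 to compound 4 (1.51 log units; beyond the scatter). The earlier compounds had shown only the single move from methyl to isopropyl on the oxygen. Pentyloxy in place of isobutyl gave a 1.7-fold lower number from compound 3 to compound 4 (0.24 log units; within the scatter), so an oxygen-linked group now matches compound 3, and the earlier advantage of isobutyl over isopropoxy does not show that the oxygen itself is a drawback.

From the compounds shown here alone, whether a chain longer than pentyl, or an amine at its end, would lower the number further remains open, as does the effect of a plain hexyl group at this position. Nothing available explains any of these steps.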